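Swapping the Nitrile for a Methyl on the Aryl Ring

This account rests on a few compounds, and the source may have more. Where it says the series, first, only, none or still open, it means among the compounds named here.

Of the compounds shown here, two sharing one core have been measured in a functional assay on mitochondria from heart for inhibition of peroxisomal acyl-coenzyme A oxidase 1 (Rattus norvegicus); on this read-out lower numbers stand for stronger inhibition and higher numbers for weaker inhibition. Compound 1 `Cc1nc2cc(OC[C@H](O)CN3CCN(Cc4noc(-c5ccc(C(C)(C)C)cc5)n4)CC3)ccc2s1` gives 180 nM. Compound 2 `Cc1nc2cc(OC[C@H](O)CN3CCN(Cc4noc(-c5ccc(C#N)cc5)n4)CC3)ccc2s1` carries a nitrile where compound 1 carries tert-butyl. In this assay compound 2 gives 4410 nM. Among the measured compounds shown here, the single step between them, a 25-fold higher number from compound 1 to compound 2 (1.39 log units; beyond the scatter), shows that the group on this outer ring matters a great deal. For the measured compounds named here, of the two numbers known so far, compound 2 stands at the highest, the weaker of the pair.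

Compound 3 `Cc1cccc(-c2nc(CN3CCN(C[C@@H](O)COc4ccc5sc(C)nc5c4)CC3)no2)c1` is the next step from compound 2: 3-methylphenyl in place of 4-cyanophenyl on an aromatic carbon. Going by the values given here, the only measured step that bears on this change is the one from compound 1 to compound 2; the new change runs in the opposite direction, removing the nitrile in favour of a group made only of carbon, though the entering group is 3-methylphenyl rather than the 4-tert-butylphenyl of compound 1. The number is therefore expected to fall, but by less than the whole of that earlier step. Compound 3 is estimated at 800 nM, within a range of 200 nM to 3500 nM, which means an expected step of a 5.5-fold lower number from compound 2 to compound 3 (0.74 log units; beyond the scatter).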

Compound 3, half-maximal inhibitory concentration: 6500 nM
The estimate for compound 3 lay 8.1-fold (0.91 log units) below the measured number; measured number outside the range, above it.
By their numbers in this assay, from the lowest: compound 1; then compounds 2 and 3 (each within the scatter of the next).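

Removing the nitrile did not by itself lower the number. In this assay, 3-methylphenyl in place of 4-cyanophenyl gives a 1.5-fold higher number from compound 2 to compound 3 (0.17 log units; within the scatter), so this change at the position on the five-membered ring leaves no difference that can be read. A group made only of carbon is therefore not enough to reach the low number of compound 1, as 3-methylphenyl in place of 4-(tert-butyl)phenyl gives a 36-fold higher number from compound 1 to compound 3 (1.56 log units; beyond the scatter); among these three compounds, only the 4-(tert-butyl)phenyl compound stands apart. Nothing measured here explains this difference.

The entering and leaving groups in this last step differ both in the carbon group on the outer ring and in where it sits, so the compounds shown cannot say which of these two differences matters more. As far as these compounds go, how the number would respond to a plain phenyl ring, or to a phenyl ring carrying an amine or a carboxylic acid, remains open.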